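Swapping a dihydroxyphenyl into a methoxy-bearing quinazoline urea

The source may report more compounds than this note shows. Statements on the series, on what has been measured and on what is new or still open speak of the compounds shown alone.

Three compounds built on one shared core were measured in a functional assay on HepG2 cells (Homo sapiens) for cytotoxicity, read by MTT assay, with a stated time of 72 h; on this read-out lower numbers stand for stronger inhibition and higher numbers for weaker inhibition. Compound 1 `O=C(N/N=C/c1cc(Br)c(O)c(Br)c1)Nc1cc2c(Nc3ccc(F)c(Cl)c3)ncnc2cc1O[C@H]1CCOC1` gives 2740 nM. Compound 2 `O=C(N/N=C/c1ccc(O)cc1O)Nc1cc2c(Nc3ccc(F)c(Cl)c3)ncnc2cc1O[C@H]1CCOC1` gives 4530 nM. Compound 3 `COc1cc2ncnc(Nc3ccc(F)c(Cl)c3)c2cc1NC(=O)N/N=C/c1cc(Br)c(O)c(Br)c1` gives 36800 nM, the highest of the three numbers.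

Compound 4 `COc1cc2ncnc(Nc3ccc(F)c(Cl)c3)c2cc1NC(=O)N/N=C/c1ccc(O)cc1O` has not been measured. It differs from compound 3 by 2,4-dihydroxyphenyl in place of 3,5-dibromo-4-hydroxyphenyl on a carbon with a double bond to nitrogen. The same change, made from compound 1 to compound 2, is 2,4-dihydroxyphenyl in place of 3,5-dibromo-4-hydroxyphenyl on a carbon with a double bond to nitrogen and produced a 1.7-fold higher number from compound 1 to compound 2 (0.22 log units; within the scatter). The two cores differ as described by methyl in place of oxolan-3-yl on an oxygen on an aromatic ring, and that difference produced a 13-fold higher number from compound 1 to compound 3 (1.13 log units; beyond the scatter). The place of the change is the same word for word in both pairs, so the change is the same.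

Because the step of a 1.7-fold higher number from compound 1 to compound 2 (0.22 log units; within the scatter) is small, the step from compound 3 to compound 4 is expected to be of similar modest size, estimated as a 1.6-fold higher number from compound 3 to compound 4 (0.21 log units; within the scatter). The expectation rests only on that one earlier step, so the range is kept wide. For compound 4 in this assay, the estimated value is 60000 nM, expected between 25000 nM and 150000 nM.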

Compound 4, half-maximal inhibitory concentration: 32100 nM
The estimate for compound 4 lay 1.9-fold (0.27 log units) above the measured number; measured number inside the range.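

In this assay, 2,4-dihydroxyphenyl in place of 3,5-dibromo-4-hydroxyphenyl gives a 1.1-fold lower number from compound 3 to compound 4 (0.06 log units; within the scatter), and this agrees with the same change on the core carrying oxolan-3-yl: the same change on two cores in this assay, a 1.7-fold higher number (0.22 log units; within the scatter) from compound 1 to compound 2 and a 1.1-fold lower number (0.06 log units; within the scatter) from compound 3 to compound 4, 1.9-fold (0.28 log units) apart, within the scatter of two such steps The other change, methyl in place of oxolan-3-yl on an oxygen on an aromatic ring, gives a 7.1-fold higher number from compound 2 to compound 4 (0.85 log units; beyond the scatter), and it too carries over from one aryl group to the other: the same change on two cores in this assay, a 13-fold higher number (1.13 log units; beyond the scatter) from compound 1 to compound 3 and a 7.1-fold higher number (0.85 log units; beyond the scatter) from compound 2 to compound 4, 1.9-fold (0.28 log units) apart, within the scatter of two such steps Within these four compounds, then, the aryl swap leaves the number within the scatter on both cores, while the oxolan-3-yl to methyl change raises it clearly with both aryl groups, but two cores cannot show that this holds on other cores, and the agreement says nothing about why the numbers move.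

The compounds shown leave open whether the weaker result with methyl would also appear with an ethyl group or a longer chain on that oxygen. They also leave open how a chain ending in an amine would behave there, or whether an unsubstituted phenyl would match the two aryl groups shown.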